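A prenyl group added to an inactive cyclodipeptide

The compounds below may be only part of what the source reports. "The series", "measured", "known", "first", "only" and "open" are said of these compounds alone.

Measured so far in a functional assay on HL-60 cells (Homo sapiens) for cytotoxicity, read by MTT assay, with a stated time of 72 h; a higher number here means a weaker inhibitor, a lower number a stronger inhibitor:
- compound 1, `C=CC(C)(C)c1[nH]c2ccc(C[C@@H](O)C(C)(C)Cl)cc2c1/C=C1\NC(=O)[C@H](C)NC1=O`: > 50000 nM, a limit of the assay
- compound 2, `C=CC(C)(C)c1[nH]c2ccc(C[C@@H](Cl)C(C)(C)O)cc2c1/C=C1\NC(=O)[C@H](C)NC1=O`: > 50000 nM, a limit of the assay
- compound 3, `C=CC(C)(C)c1[nH]c2ccccc2c1/C=C1\NC(=O)C(C)(OC)NC1=O`: > 50000 nM, a limit of the assay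

Compound 3 thus sits at the ceiling of this assay, and so do the other two values shown (the limit of > 50000 nM in this assay, at which 3 of the 3 values shown sit). The step from compound 1 to compound 2 in this assay, a step that the two limits leave unreadable from compound 1 to compound 2, cannot be sized.

Compound 4, `C=CC(C)(C)c1[nH]c2ccc(CC=C(C)C)cc2c1/C=C1\NC(=O)C(C)(OC)NC1=O`, differs from compound 3 by 3-methylbut-2-en-1-yl in place of hydrogen on an aromatic carbon. Going by the values given here, no measured step involves this change, so there is no basis to expect a move beyond the scatter in this assay. The step of a number no higher from compound 3 to compound 4 (the limit leaves the size open) is expected to be flat. Compound 4 is estimated at 50000 nM, within 15000 nM to 100000 nM, most likely again as a limit.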

Compound 4, half-maximal inhibitory concentration: > 50000 nM
Compound 4 ended at the assay's limit; the forecaster's own chance of this, stated with the estimate: 75%; the middle value lies on the limit itself.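

Going by these compounds alone, no step from compound 3 to compound 4 can be read in this assay because both sit at the same ceiling: the limit of > 50000 nM in this assay, at which 4 of the 4 values shown sit.

On these data alone, whether 3-methylbut-2-en-1-yl in place of hydrogen changes cytotoxicity at all stays open.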